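A Morpholine Amide Replaces a Piperidine Amide

A few compounds are considered here, and "the series" means these few. Any claim that something is new, unique, unknown or untested is made for them only; others in the source may bear on it.

Of the compounds shown here, two have been measured in an assay on isolated protein for inhibition of thyroid hormone receptor beta (Homo sapiens), read by fluorescence, with a stated time of 30 min; on this read-out higher numbers stand for weaker inhibition and lower numbers for stronger inhibition. Compound 1 `COc1cc(C(=O)N2CCC(O)C(C)C2)cc2nc(NCc3cc(Cl)ccn3)oc12` gives 190 nM. Compound 2 `COc1cc(C(=O)N2CCC(O)C(C)C2)cn2nc(NCc3cccc(Cl)c3)nc12` gives 470 nM, the higher of the two numbers, and the gap between these two values lies beyond the scatter. Compound 3 `COc1cc(C(=O)N2CC(C)OCC2CCO)cn2nc(NCc3cccc(Cl)c3)nc12` differs from compound 2 in one place: 5-(2-hydroxyethyl)-2-methylmorpholin-4-yl in place of 4-hydroxy-3-methylpiperidin-1-yl on a carbonyl carbon. Going by the values given here, with no step of this kind among the measured compounds, the expected change is a 1.3-fold higher number from compound 2 to compound 3 (0.11 log units; within the scatter), a step no larger than the scatter, without a clear direction. Compound 3 is therefore estimated at 600 nM, within a range from 200 nM to 1800 nM.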

Compound 3, half-maximal inhibitory concentration: 52 nM
Estimate against measurement, compound 3: 12-fold (1.06 log units) above; measured number outside the range, below it.
By their numbers in this assay, from the lowest: compound 3; then compound 1; then compound 2.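

Compound 1 and compound 2 carry the same 4-hydroxy-3-methylpiperidin-1-yl on the carbonyl carbon, so they showed nothing about this position. In this assay 5-(2-hydroxyethyl)-2-methylmorpholin-4-yl in its place gives a 9.0-fold lower number from compound 2 to compound 3 (0.96 log units; beyond the scatter) and so the position responds to change, and the group with more heavy atoms is tolerated here.

Going by these compounds, whether the ring oxygen or the 2-hydroxyethyl chain carries this step stays open, as does what a 3-hydroxypropyl chain or a carboxylic acid on that chain would give. No measurement at hand explains the step.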